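One Added Methyl on the Methoxy Group of Compound 2

The source may report more compounds than this note shows. Statements on the series, on what has been measured and on what is new or still open speak of the compounds shown alone.

Among the measured compounds shown here, in a functional assay on HCT-116 cells (Homo sapiens) for inhibition, read by luminescence and CellTiter-Glo, with a stated time of 72 h (on this read-out lower numbers stand for stronger inhibition and higher numbers for weaker inhibition), compound 1 `Cc1cc2c(NC(=O)c3ccco3)cccc2n1-c1nc2c(c(NCc3cccc(O)c3)n1)CCC2` gives 1200 nM and compound 2 `CONC(=O)c1cccc2c1cc(C)n2-c1nc2c(c(NCc3cccc(O)c3)n1)CCC2` gives 300 nM as the lower of the two numbers so far. Compound 3 `CCONC(=O)c1cccc2c1cc(C)n2-c1nc2c(c(NCc3cccc(O)c3)n1)CCC2` has not yet been measured. It differs from compound 2 by methyl in place of hydrogen on a saturated chain carbon bound to an oxygen on an unsaturated carbon with methyl in place of hydrogen on a saturated chain carbon bound to an oxygen on an unsaturated carbon, which turns methoxy into ethoxy. For the measured compounds named here, the only measured step is a 4.0-fold lower number from compound 1 to compound 2 (0.60 log units; beyond the scatter) and it exchanges a whole group, so it says little about one added methyl. Going by the values given here, no measured pair isolates such a change. A small step is therefore expected, probably within the scatter, and the data favour no direction. The estimate amounts to an expected 1.2-fold higher number from compound 2 to compound 3 (0.07 log units; within the scatter) and no more. Compound 3 is expected near 350 nM as the estimated value, with an estimated range of 130 nM to 900 nM for its measurement.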

Compound 3, half-maximal inhibitory concentration: 600 nM
The estimate for compound 3 lay 1.7-fold (0.23 log units) below the measured number; the measured number falls inside the stated range.
By their numbers in this assay, from the lowest: compounds 2, 3 and 1 (each within the scatter of the next, the first and the last beyond it).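

In this assay, among the compounds shown here, the one change confined to this chain, methoxy to ethoxy, gives a 2.0-fold higher number from compound 2 to compound 3 (0.30 log units; within the scatter), so adding one methyl on the saturated chain carbon bound to an oxygen produces a step that this read-out does not separate from repeat measurement. Replacing ((furan-2-yl)carbonyl)amino with methoxycarbamoyl gave a 4.0-fold lower number from compound 1 to compound 2 (0.60 log units; beyond the scatter), whereas replacing it with ethoxycarbamoyl gives a 2.0-fold lower number from compound 1 to compound 3 (0.30 log units; within the scatter), so only the methoxycarbamoyl exchange is resolved from compound 1. No measured evidence bears on the reason for these numbers.

The compounds shown leave open how a longer chain, such as propoxy, or a branched isopropoxy group would read at this oxygen. With methoxy and ethoxy alone, no trend along the chain can be stated.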